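A few compounds are considered here, and "the series" means these few. Any claim that something is new, unique, unknown or untested is made for them only; others in the source may bear on it.

Series notes. The shared core of compound 1 `CN1C(=S)[C@@H](NC(=O)c2nc(Cc3ccccc3)n(C)n2)COc2ccccc21` carries a saturated chain carbon bound to an aromatic nitrogen; compound 1 has hydrogen at that carbon, compound 2 `CCCn1nc(C(=O)N[C@H]2COc3ccccc3N(C)C2=S)nc1Cc1ccccc1` has ethyl in place of hydrogen there, and compound 3 `CCCCCn1nc(C(=O)N[C@H]2COc3ccccc3N(C)C2=S)nc1Cc1ccccc1` has butyl in place of hydrogen there. In a toxicity assay on HT-29 cells (Homo sapiens) for cytotoxicity (on this read-out higher numbers stand for lower toxicity in this test and lower numbers for higher toxicity in this test), compound 1 reports only a limit, > 100000 nM. Compound 2 likewise reports only a limit in this assay, namely > 100000 nM. Compound 3 too reports only a limit in this assay, namely > 100000 nM. The steps a step that the two limits leave unreadable from compound 1 to compound 2, a step that the two limits leave unreadable from compound 1 to compound 3 and a step that the two limits leave unreadable from compound 2 to compound 3 are therefore all unreadable in size, since every value rests at the limit of > 100000 nM in this assay, at which 3 of the 3 values shown sit. Compound 3 thus stands at that limit with no number of its own, in the same place as the other two.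

Compound 4 `COCCn1nc(C(=O)N[C@H]2COc3ccccc3N(C)C2=S)nc1Cc1ccccc1` differs from compound 3 by methoxy in place of propyl on a saturated chain carbon, two bonds along the chain from an aromatic nitrogen. All three measured steps bear on chain changes at or near this position, and none of them yielded a readable size, so no step beyond the scatter is expected in this assay in either direction. Compound 4 is accordingly estimated at 120000 nM, within a range from 50000 nM to 400000 nM, and most probably will again be reported only as a limit. The expected step from compound 3 is a step that the limit leaves unreadable from compound 3 to compound 4.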

Compound 4, half-maximal cytotoxic concentration: > 100000 nM
Compound 4: a limit, no number; the forecaster's own chance of this, stated with the estimate: 85%; the middle value does not contradict the limit.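

In this assay compound 4 gives > 100000 nM, a limit and not a number. Its steps from compound 1, compound 2 and compound 3 cannot be read in size, because all the values rest at one limit: the limit of > 100000 nM in this assay, at which 4 of the 4 values shown sit.

The compounds shown leave open whether any of these chains changes the read-out at all: none gives a number of its own.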